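A few compounds are considered here, and "the series" means these few. Any claim that something is new, unique, unknown or untested is made for them only; others in the source may bear on it.

In a functional assay on NALM-6 cells (Homo sapiens) for cytotoxicity, read by luminescence and CellTiter-Glo, with a stated time of 3 days (a lower number here means a stronger inhibitor, a higher number a weaker inhibitor), compound 1 (`O=C(Nc1ccc(C(F)(F)F)cc1)c1cc(Cl)ccc1O`) gives 1210 nM and compound 2 (`O=C(Nc1ccc(C(F)(F)F)cc1)c1cc(Br)c(F)cc1O`) gives 1300 nM, so compound 2 stands level with compound 1 within the usual scatter of repeated measurements. Compound 3 (`O=C(Nc1ccc(C(F)(F)F)cc1)c1cc(Br)ccc1O`) is compound 2 with one small change: hydrogen in place of fluoro on an aromatic carbon. Within the data shown here, no measured pair shows this change on its own, so the expectation in this assay is no step beyond the scatter, in either direction. The expected 1.1-fold lower number from compound 2 to compound 3 (0.03 log units; within the scatter) is therefore small. For compound 3 the estimated value is 1200 nM, with a range of 500 nM to 2900 nM.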

Compound 3, half-maximal inhibitory concentration: 1090 nM
Beside the measured number, compound 3's estimate is 1.1-fold (0.04 log units) above it, and the stated range covers the measured number.
By their numbers in this assay, from the lowest: compounds 3, 1 and 2 (each within the scatter of the next).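

In this assay, hydrogen in place of fluoro at this position, ortho to a bromo group and para to a large group, gives a 1.2-fold lower number from compound 2 to compound 3 (0.08 log units; within the scatter), so the fluoro leaves no readable mark here. Bromo in place of chloro on an aromatic carbon gives a 1.1-fold lower number from compound 1 to compound 3 (0.05 log units; within the scatter), so these two halogens cannot be told apart in this assay. Nothing measured here offers an explanation for either result. The compounds shown leave open whether an amine, a carboxylic acid or a methoxy group on the carbon that carries the fluoro in compound 2 would shift the number beyond the scatter.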